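Ring-nitrogen aryl swap: from compound 2 to compound 3

The compounds below may be only part of what the source reports. "The series", "measured", "known", "first", "only" and "open" are said of these compounds alone.

Going by the values given here, compound 2 `N#Cc1c(Nc2ccc(Cl)cc2)nc(SCc2cn(Cc3ccccc3Cl)nn2)nc1-c1ccccc1` holds the lowest of the two numbers so far, giving 1420 nM in a functional assay on ECa-109 cells (Homo sapiens) for inhibition, read by MTT assay, with a stated time of 72 h; a higher number here means a weaker inhibitor, a lower number a stronger inhibitor. Compound 1 `N#Cc1c(Nc2ccccc2Cl)nc(SCc2cn(Cc3ccccc3Cl)nn2)nc1-c1ccccc1` gives 28500 nM in this assay. Among the compounds with values here, the single measured step, a 20-fold lower number from compound 1 to compound 2 (1.30 log units; beyond the scatter), is the only guide here. Compound 3 `COc1ccccc1Nc1nc(SCc2cn(Cc3ccccc3Cl)nn2)nc(-c2ccccc2)c1C#N` carries 2-methoxyphenyl in place of 4-chlorophenyl on a nitrogen on an aromatic ring. This change gives up the 4-chlorophenyl that was rewarded in a 20-fold lower number from compound 1 to compound 2 (1.30 log units; beyond the scatter), so a higher number, beyond the scatter, is expected, with the step estimated as an 8.5-fold higher number from compound 2 to compound 3 (0.93 log units; beyond the scatter). For compound 3 the expected value in this assay is 12000 nM, within a range of 2500 nM to 50000 nM.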

Compound 3, half-maximal inhibitory concentration: 9670 nM
Compound 3: the middle estimate sits 1.2-fold (0.09 log units) above what was measured, within the range that was stated.
By their numbers in this assay, from the lowest: compound 2; then compound 3; then compound 1.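

With the 2-methoxyphenyl on this nitrogen, the series gives a 6.8-fold higher number from compound 2 to compound 3 (0.83 log units; beyond the scatter) and so stays on the weaker side of the 4-chlorophenyl of compound 2, which holds the lowest number of the three. Methoxy in place of chloro on an aromatic carbon gives a 2.9-fold lower number from compound 1 to compound 3 (0.47 log units; beyond the scatter) and shows that the group itself counts, even with its place on the phenyl ring unchanged. Going by these compounds, how an amine or a carboxylic acid on this phenyl ring would read in this assay stays open. Nothing at hand accounts for either step.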